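This account rests on a few compounds, and the source may have more. Where it says the series, first, only, none or still open, it means among the compounds named here.

Compound 1 `CN(C)c1ccc(CN(Cc2ccc(C(=O)NO)cc2)S(=O)(=O)c2c(F)c(F)c(F)c(F)c2F)cc1`: > 1000 nM
Compound 2 `O=C(NO)c1ccc(CN(Cc2ccncc2)S(=O)(=O)c2c(F)c(F)c(F)c(F)c2F)cc1`: > 1000 nM

In an assay on isolated protein for inhibition of histone deacetylase 8 (Homo sapiens), read by mobility shift assay (a lower number here means a stronger inhibitor, a higher number a weaker inhibitor), compound 1 gives > 1000 nM, and this is a limit of the assay rather than a number. In this assay compound 2 gives > 1000 nM, again a limit and not a number. Going by the values given here, both values sit at the limit of > 1000 nM in this assay, at which 2 of the 2 values shown sit, so compound 2 stands only at a limit, and the one measured step, a step that the two limits leave unreadable from compound 1 to compound 2, cannot be sized: it is known neither in direction nor in magnitude.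

Compound 3 `O=C(NO)c1ccc(CN(Cc2ccncc2)S(=O)(=O)c2cc(F)c(F)c(F)c2F)cc1` differs from compound 2 by hydrogen in place of fluoro on an aromatic carbon. No measured step tells how such a change moves the read-out, and the only step shown is unreadable, so no direction beyond the scatter can be expected from the data. In this assay compound 3 is therefore estimated to give 2000 nM, within 500 nM to 10000 nM. The step that the limit leaves unreadable from compound 2 to compound 3 that this estimate means is expected to stay inside the scatter.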

Compound 3, half-maximal inhibitory concentration: 581 nM
Compound 3: the middle estimate sits 3.4-fold (0.54 log units) above what was measured, and the stated range covers the measured number.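

In this assay compound 3 gives 581 nM, the only true number among the compounds shown. Compound 1 and compound 2 stand only at a limit of the assay: the limit of > 1000 nM in this assay, at which 2 of the 3 values shown sit. Going from 2,3,4,5,6-pentafluorophenyl to 2,3,4,5-tetrafluorophenyl, with hydrogen in place of the fluoro that sits ortho to a large group, gives an at least 1.7-fold lower number from compound 2 to compound 3 (0.23 log units; that floor lies within the scatter), the first step here that can be read at all. That figure is only a floor, so the real step may be larger, but the floor itself lies within the scatter.

From the compounds shown here alone, it remains open whether a chlorine atom, a methyl group or a methoxy group on this same carbon would read like hydrogen or like fluoro. Also open, going by these compounds, is whether the same change would give a readable number with the 4-(dimethylamino)phenyl group of compound 1 in place of pyridin-4-yl.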